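This account rests on a few compounds, and the source may have more. Where it says the series, first, only, none or still open, it means among the compounds named here.

Of the compounds shown here, two that share one core have been measured in a functional assay on A549 cells (Homo sapiens) for cytotoxicity, read by XTT assay, with a stated time of 72 h; on this read-out lower numbers stand for stronger inhibition and higher numbers for weaker inhibition. Compound 1 `CCCN(C)C(=O)c1ccc(-c2cc(-c3cc(OC)ccc3OC)no2)s1` carries a methyl(propyl)amino group on its carbonyl carbon. In this assay compound 1 reaches only a limit, > 30000 nM. Compound 2 `COc1ccc(OC)c(-c2cc(-c3ccc(C(=O)N4CCCCC4)s3)on2)c1` bears piperidin-1-yl in place of methyl(propyl)amino on that carbonyl carbon. In this assay compound 2 likewise stops at a limit, > 30000 nM. The step that the two limits leave unreadable from compound 1 to compound 2 therefore cannot be read in size or direction: both values sit at the limit of > 30000 nM in this assay, at which 2 of the 2 values shown sit. Compound 3 `COc1ccc(OC)c(-c2cc(-c3ccc(C(=O)N4CCC(C(F)(F)F)CC4)s3)on2)c1` has not yet been measured. It differs from compound 2 by trifluoromethyl in place of hydrogen on a saturated ring carbon of the piperidin-1-yl ring. For the measured compounds named here, no measured step covers this kind of change, and the single step that exists in this assay is unreadable, so it offers no guide to how far or in which direction the number might move. With both known values at a limit, compound 3 is expected to give about 40000 nM in this assay, within a range from 10000 nM to 150000 nM. The step that the limit leaves unreadable from compound 2 to compound 3 is accordingly expected to stay within the scatter.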

Compound 3, half-maximal inhibitory concentration: > 30000 nM
Compound 3 ended at the assay's limit (the forecaster's own chance of this, stated with the estimate: 70%); the middle value is on the limit's open side.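

In this assay compound 3 also reaches only a limit, > 30000 nM. The steps to compound 3 from compound 1 and from compound 2 therefore cannot be read in size or direction: the limit of > 30000 nM in this assay, at which 3 of the 3 values shown sit. The compounds shown leave open how strongly any of them acts on these cells, and whether these changes move that number at all.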